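Removing the Fluorine from a Fluoroketone Amide

This account rests on a few compounds, and the source may have more. Where it says the series, first, only, none or still open, it means among the compounds named here.

Of the compounds shown here, two have been measured in an assay on HEK-293T cells for inhibition of phospholipase A and acyltransferase 5 (Homo sapiens), with stated times of 30 min and 20 min; on this read-out lower numbers stand for stronger inhibition and higher numbers for weaker inhibition. Compound 1 `O=C(CCc1ccccc1)C(F)(F)C(=O)NCc1ccccc1` gives > 10000 nM in this assay, which is a limit of the assay rather than a number. Compound 2 `O=C(CCc1ccccc1)[C@H](F)C(=O)NCc1ccccc1` likewise gives > 10000 nM, again a limit. The picture so far is the limit of > 10000 nM in this assay, at which 2 of the 2 values shown sit. Compound 3 `O=C(CCc1ccccc1)CC(=O)NCc1ccccc1` differs from compound 2 by hydrogen in place of fluoro on a saturated chain carbon bound to two carbonyl carbons. No shift beyond the scatter is expected, with the step estimated at a step that the limit leaves unreadable from compound 2 to compound 3. Compound 3 is expected to give about 15000 nM, between 5000 nM and 50000 nM, most likely again only a limit.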

Compound 3, half-maximal inhibitory concentration: > 10000 nM
Compound 3: no number, only a limit; the forecaster's own chance of this, stated with the estimate: 85%; the middle value is on the limit's open side.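

Within the data shown here, compound 3 gives > 10000 nM in this assay, a limit and not a number, so no step from compound 2 to it can be read. The compounds shown leave open how strongly any of them inhibits, since all rest at one limit: the limit of > 10000 nM in this assay, at which 3 of the 3 values shown sit.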